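The compounds below may be only part of what the source reports. "The series", "measured", "known", "first", "only" and "open" are said of these compounds alone.

Of the compounds shown here, three on a shared core have been tested in a functional assay on HepG2 cells (Homo sapiens) for cytotoxicity, with a stated time of 72 h (a higher number here means that more compound is needed for the effect, a lower number that less compound is needed), so far. Compound 1 `COc1ccc(/C=C/[C@@](C)(/C=C/c2ccc(O)c(C=O)c2)CCC=C(C)C)cc1` carries a formyl group and reads > 26000 nM as a limit of the assay. Compound 2 `COc1ccc(/C=C/[C@@](C)(/C=C/c2ccc(O)c(/C=C/C#N)c2)CCC=C(C)C)cc1` carries 2-cyanoethenyl there and reads > 26000 nM as a limit too. Compound 3 `COc1ccc(/C=C/[C@@](C)(/C=C/c2ccc(O)c(/C=C/C(=O)OC(C)(C)C)c2)CCC=C(C)C)cc1` carries 2-(tert-butoxycarbonyl)ethenyl and reads > 52000 nM as a limit as well, so its standing is known only as a limit, as with the other two.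

Compound 4 `COc1ccc(/C=C/[C@@](C)(/C=C/c2ccc(O)c(/C=C/C(C)=O)c2)CCC=C(C)C)cc1` departs from compound 3 by one change: methyl in place of tert-butoxy on a carbonyl carbon with methyl in place of tert-butoxy on a carbonyl carbon, so that tert-butoxycarbonyl becomes acetyl.

The closest measured change is a step that the two limits leave unreadable from compound 2 to compound 3 and it concerns the same chain. The others are a step that the two limits leave unreadable from compound 1 to compound 2 and a step that the two limits leave unreadable from compound 1 to compound 3 and they give no size either. Among the measured compounds shown here, no measured step therefore supports a direction, and the expected at least 1.7-fold lower number from compound 3 to compound 4 (0.23 log units; that floor lies within the scatter) is only a rough guess. The estimate for compound 4 is 30000 nM with an expected range from 12000 nM to 60000 nM and a limit is the likeliest report.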

Compound 4, half-maximal effective concentration: > 52000 nM
Compound 4 was reported as a limit; the forecaster's own chance of this, stated with the estimate: 70%; at least 1.7-fold (0.23 log units) between middle value and limit.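

Compound 4 also gives only a limit, so its steps from compound 1, compound 2 and compound 3 cannot be read in size: the limit of > 52000 nM in this assay, at which 2 of the 4 values shown sit. The compounds shown leave open whether formyl, 2-cyanoethenyl, 2-(tert-butoxycarbonyl)ethenyl and 2-acetylethenyl differ at all in this assay, where each compound gives only a limit.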